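Series notes: carbonyl substituent change from compound 3 to compound 4

This account rests on a few compounds, and the source may have more. Where it says the series, first, only, none or still open, it means among the compounds named here.

Three compounds have numbers in a functional assay on PC-3 cells (Homo sapiens) for cytotoxicity, read by MTT assay, with a stated time of 48 h; on this read-out lower numbers stand for stronger inhibition and higher numbers for weaker inhibition. Compound 1 `CC1=NN(C(=O)COc2ccc(Cl)cc2)C(c2ccccc2O)C1` gives 38800 nM. Compound 2 `CC1=NN(C(=O)CCl)C(c2cc(Br)ccc2O)C1` gives 8890 nM in this assay. Compound 3 `O=C(c1ccccc1Cl)N1N=C(c2cc3ccccc3oc2=O)CC1c1ccccc1` gives 6370 nM in this assay, the lowest of the three numbers; its gap to compound 2 lies within the scatter, so no order between those two can be read, whereas its gap to compound 1 lies beyond the scatter. Among the measured compounds shown here, no two of the measured compounds differ in a single place, so no measured step is available in this set.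

Compound 4 `CC1CCCN(CC(=O)N2N=C(c3cc4ccccc4oc3=O)CC2c2ccccc2)C1` has not been measured. It differs from compound 3 in one place: (3-methylpiperidin-1-yl)methyl in place of 2-chlorophenyl on a carbonyl carbon. For the measured compounds named here, no measured compound carries a group of this kind on that carbonyl carbon, so there is no step to lean on, and any expectation rests on compound 3 alone.

The step in this assay is expected to be small, a 1.3-fold higher number from compound 3 to compound 4 (0.10 log units; within the scatter), with no direction claimed beyond the scatter. Compound 4 is accordingly estimated at 8000 nM, within a range from 2500 nM to 25000 nM, the width of that range reflecting that nothing measured informs this particular change.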

Compound 4, half-maximal inhibitory concentration: 28300 nM
Estimate against measurement, compound 4: 3.5-fold (0.55 log units) below; the whole stated range lies below it.
By their numbers in this assay, from the lowest: compounds 3 and 2 (each within the scatter of the next); then compounds 4 and 1 (each within the scatter of the next).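

In this assay, the carbonyl carbon on the amide-type ring nitrogen is shown to respond to its substituent: (3-methylpiperidin-1-yl)methyl in place of 2-chlorophenyl gives a 4.4-fold higher number from compound 3 to compound 4 (0.65 log units; beyond the scatter), and this is the first single-place step in the series, lying beyond the scatter. On this core, the 2-chlorophenyl group therefore gives the lower number of the two, but the change replaces a six-membered aromatic ring of carbon only with a six-membered non-aromatic ring containing a hetero atom and also brings in a methyl-bearing chain, so this one step cannot assign the rise to any single part of the group. No supporting measurement bears on the reason for the step.

Still open, as far as these compounds go, is whether the ring nitrogen, the non-aromatic ring or the extra carbon on the carbonyl carbon accounts for the higher number, which a benzyl group or an unsubstituted piperidin-1-ylmethyl group at the same place could help separate. Also open, from the compounds shown here alone, is whether the 2-chloro substituent itself contributes, a question that a plain phenyl or a 2-methoxyphenyl group on that carbonyl carbon would address.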